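This account rests on a few compounds, and the source may have more. Where it says the series, first, only, none or still open, it means among the compounds named here.

Compound 1 `Cc1nn(C)c(C(=O)NCc2ccc(Oc3ccc(Cl)cc3)cc2)c1Cl` and compound 2 `CCc1nn(C)c(C(=O)NCc2ccc(Oc3ccc(Cl)cc3)cc2)c1Cl` share one core and differ in a single group. In a toxicity assay on MCF-10A cells (Homo sapiens) for cytotoxicity (on this read-out lower numbers stand for stronger inhibition and higher numbers for weaker inhibition), compound 1 gives 50000 nM, while compound 2 gives 8700 nM. Compound 3 `Cn1ncc(Cl)c1C(=O)NCc1ccc(Oc2ccc(Cl)cc2)cc1` carries a hydrogen where the others carry methyl or ethyl. In this assay compound 3 reaches only a limit of the measurement, not a number, at > 50000 nM. Compound 3 therefore stands at the limit of > 50000 nM in this assay, at which 1 of the 3 values shown sits, among the weakest numbers shown. Between the measured compounds the steps were a 5.7-fold lower number from compound 1 to compound 2 (0.76 log units; beyond the scatter), an at least 5.7-fold higher number from compound 2 to compound 3 (0.75 log units; beyond the scatter) and a number no lower from compound 1 to compound 3 (the limit leaves the size open).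

Compound 4 `Cn1ncc(Cl)c1C(=O)NCc1ccc(-c2noc(C3CC3)n2)cc1` has not yet been measured. Relative to compound 3 the change is 5-cyclopropyl-1,2,4-oxadiazol-3-yl in place of 4-chlorophenoxy on an aromatic carbon. Among the compounds with values here, all three measured steps concern the methyl, ethyl or hydrogen on the core and leave the 4-chlorophenoxy group untouched, so no measured step bears directly on this change, and no shift beyond the scatter is expected. The estimated step is a number no higher from compound 3 to compound 4 (the limit leaves the size open). Compound 4 is estimated at 50000 nM, between 15000 nM and 100000 nM, most likely again reported only as a limit.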

Compound 4, half-maximal inhibitory concentration: 24300 nM
Estimate against measurement, compound 4: 2.1-fold (0.31 log units) above; the range from low to high includes it.
By their numbers in this assay, from the lowest: compound 2; then compound 4; then compound 1.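

Within the data shown here, the earlier compounds changed only the methyl, ethyl or hydrogen on the shared core, so compound 4 is the first to show that the group on the other aromatic ring also affects the number in this assay. Replacing 4-chlorophenoxy with 5-cyclopropyl-1,2,4-oxadiazol-3-yl, which has the same heavy-atom count but more hydrogen-bond acceptors, gives an at least 2.0-fold lower number from compound 3 to compound 4 (0.31 log units; beyond the scatter). The true size of this step stays open, as compound 3 is a limit of the measurement and not a number: the limit of > 50000 nM in this assay, at which 1 of the 4 values shown sits.

The compounds shown do not separate the cyclopropyl from the five-membered aromatic ring that carries it, nor show whether an amine or a carboxylic acid at this place would give a similar number. They also leave open whether ethyl on the core would lower the number in the presence of the new group, as it does with 4-chlorophenoxy.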